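The compounds below may be only part of what the source reports. "The series", "measured", "known", "first", "only" and "open" are said of these compounds alone.

- Compound 1 (`CC[C@@H](c1ccc(C(=O)O)c(Oc2cccc(Cl)c2)c1F)N1CCC[C@H](n2cc(C)c(=O)[nH]c2=O)C1`): 0.11
- Compound 2 (`Cc1cn([C@H]2CCCN([C@@H](CC(C)C)c3ccc(C(=O)O)c(Oc4cccc(Cl)c4)c3F)C2)c(=O)[nH]c1=O`): 0.57

In a physicochemical assay for lipophilicity, using the shake flask method, in phosphate buffer, measured as octanol-water partition, at pH 7.4 (on this read-out lower numbers stand for lower lipophilicity and higher numbers for higher lipophilicity), compound 2 gives the higher of the two numbers, 0.57. Compound 3 (`CCC[C@@H](c1ccc(C(=O)O)c(Oc2cccc(Cl)c2)c1F)N1CCC[C@H](n2cc(C)c(=O)[nH]c2=O)C1`) differs from it by hydrogen in place of methyl on a saturated chain carbon bound to two saturated chain carbons, turning isobutyl into propyl. Going by the values given here, one measured step bears on this change: a number 0.46 log units higher from compound 1 to compound 2 (beyond the scatter), a modest rise with isopropyl in place of methyl. Removing part of that larger addition should undo part of the rise, so a smaller downward step is expected, possibly within the scatter. The expected change is a number 0.22 log units lower from compound 2 to compound 3 (within the scatter). Compound 3 is estimated at 0.35, with an expected range of 0.1 to 0.6.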

Compound 3, distribution coefficient: 0.51
For compound 3 the middle estimate is 0.16 log units below the measured one; the range from low to high includes it.
By their numbers in this assay, from the lowest: compound 1; then compounds 3 and 2 (each within the scatter of the next).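

Going from isobutyl to propyl gives a number 0.06 log units lower from compound 2 to compound 3 (within the scatter) in this assay and leaves the number indistinguishable from that of the branched chain. By contrast, methyl in place of hydrogen gives a number 0.40 log units higher from compound 1 to compound 3 (beyond the scatter) at the neighbouring place on the chain, so the earlier rise from compound 1 to compound 2 is matched, within the scatter, by the unbranched propyl chain of compound 3. Nothing available explains why these two steps differ.

Still open, from the compounds shown here alone, is whether a longer chain, or a chain ending in an amine or a hydroxyl group, would shift the number in this assay at all.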